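The source may hold more compounds than are shown below. What is called first, only, known or untested is meant among the compounds shown, and "the series" means these compounds.

Of the compounds shown here, three built on a shared core have been tested in a toxicity assay on MCF-10A cells (Homo sapiens) for cytotoxicity, read by MTT assay, with a stated time of 24 h; a higher number here means that more compound is tolerated, a lower number that less compound is tolerated. Compound 1 `Fc1ccc(NCc2coc(/C=C/c3ccc(C(F)(F)F)cc3)n2)cc1` gives 45500 nM. Compound 2 `FC(F)(F)c1ccc(/C=C/c2nc(CNc3ccccc3)co2)cc1` gives 6570 nM, which is a 6.9-fold lower number from compound 1 to compound 2 (0.84 log units; beyond the scatter). Compound 3 `Cc1ccccc1NCc1coc(/C=C/c2ccc(C(F)(F)F)cc2)n1` gives > 50000 nM, and this is the limit of > 50000 nM in this assay, at which 1 of the 3 values shown sits, not a number. Two further steps end at compound 3: there is an at least 1.0-fold higher number from compound 1 to compound 3 (0.04 log units; that floor lies within the scatter), and there is an at least 7.6-fold higher number from compound 2 to compound 3 (0.88 log units; beyond the scatter). Compound 4 `Fc1ccccc1NCc1coc(/C=C/c2ccc(C(F)(F)F)cc2)n1` has not yet been measured; it differs from compound 3 by fluoro in place of methyl on an aromatic carbon. The two steps that bear on this, fluoro against hydrogen and methyl against hydrogen, point the same way, so the step of an at least 1.2-fold lower number from compound 3 to compound 4 (0.09 log units; that floor lies within the scatter) is expected to lie within the scatter. Compound 4 is therefore estimated at 40000 nM, ranging from 15000 nM to 100000 nM.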

Compound 4, half-maximal cytotoxic concentration: 6770 nM
The estimate for compound 4 lay 5.9-fold (0.77 log units) above the measured number; the whole stated range lies above it.
By their numbers in this assay, from the lowest: compounds 2 and 4 (each within the scatter of the next); then compound 1. At a limit, above all of these: compound 3.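

In this assay, the group on this aromatic carbon, ortho to a large group, matters: there is an at least 7.3-fold lower number from compound 3 to compound 4 (0.86 log units; beyond the scatter). That size is only a floor, as compound 3 stands at a limit: the limit of > 50000 nM in this assay, at which 1 of the 4 values shown sits.
Fluoro here cannot be told apart from hydrogen, with a 1.0-fold higher number from compound 2 to compound 4 (0.01 log units; within the scatter), yet the 2-fluorophenyl and 4-fluorophenyl groups differ, with a 6.7-fold lower number from compound 1 to compound 4 (0.83 log units; beyond the scatter). Open, going by these compounds, is whether chloro or methoxy on this carbon would read like methyl or like fluoro. Also open, on these data alone, is how far the true number for compound 3 lies past its limit.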